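The source may hold more compounds than are shown below. What is called first, only, known or untested is meant among the compounds shown, and "the series" means these compounds.

Compound 1 `COc1cccc(/C=C2\CCCc3ccccc3C2=O)c1OC`: 142000 nM
Compound 2 `O=C1/C(=C/c2ccccc2Cl)Cc2ccccc21`: 57000 nM
Compound 3 `O=C1/C(=C/c2ccccc2F)Cc2ccccc21`: 47100 nM

Within the data shown here, all three numbers come from a functional assay on CCRF-CEM cells (Homo sapiens) for inhibition (on this read-out lower numbers stand for stronger inhibition and higher numbers for weaker inhibition), and are the only measurements available so far. Compound 2 at 57000 nM lies within the scatter of compound 3 at 47100 nM on this read-out. Against these two, compound 1 shows a higher number at 142000 nM in the same measurement.

Compound 4 `O=C1/C(=C/c2ccc(Cl)cc2Cl)Cc2ccccc21` differs from compound 2 by one change, chloro in place of hydrogen on an aromatic carbon in words chloro in place of hydrogen on an aromatic carbon. Among the measured compounds shown here, only one measured step bears on this change, and only loosely. That step is a 1.2-fold lower number from compound 2 to compound 3 (0.08 log units; within the scatter) and it lies within the scatter, but it exchanges one halogen for another rather than adding a group. For the measured compounds named here, no measured step adds a chloro to an aromatic carbon. A small step with no firm direction is therefore expected in this assay and the estimate is a 1.3-fold lower number from compound 2 to compound 4 (0.10 log units; within the scatter) on these grounds. The expected value for compound 4 is 45000 nM with an estimated range from 18000 nM to 110000 nM.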

Compound 4, half-maximal inhibitory concentration: > 500000 nM
Compound 4: no number, only a limit; the forecaster's own chance of this, stated with the estimate: 10%; middle value at least 11-fold (1.04 log units) away from the limit.
By their numbers in this assay, from the lowest: compounds 3 and 2 (each within the scatter of the next); then compound 1. At a limit, above all of these: compound 4.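

In this assay, chloro in place of hydrogen on an aromatic carbon, meta to a chloro group and para to a large group, gives an at least 8.7-fold higher number from compound 2 to compound 4 (0.94 log units; beyond the scatter). Among these compounds, this is the first measured addition of a group, and it shifts the read-out towards weaker inhibition beyond the scatter, whereas the only earlier step, exchanging one halogen for another, gave a 1.2-fold lower number from compound 2 to compound 3 (0.08 log units; within the scatter) and stayed within the scatter. Compound 4 has only a limit, > 500000 nM, and not a number, so the full size of the step cannot be read, and it is the only limit among the values shown: the limit of > 500000 nM in this assay, at which 1 of the 4 values shown sits.

The compounds shown leave open whether this drop belongs to chloro itself or to any group at this place. A single step cannot say how a methoxy group, an amine or a carboxylic acid would behave there.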